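Anilide replacements at the carbonyl of compound 1

A few compounds are considered here, and "the series" means these few. Any claim that something is new, unique, unknown or untested is made for them only; others in the source may bear on it.

For the measured compounds named here, compound 1 `CC(=O)Nc1ccc(Cc2noc(CCC(=O)O)n2)cc1` gives 75.3% in a functional assay on the whole organism (strain C57BL/6) for inhibition, with Mus musculus as the target, read by paw edema, with stated times of 1 h and 4 h, at a dose of 100 mg/kg by the oral route (a lower number here means less inhibition, a higher number more inhibition at the dose given (going by the name of the read-out)), the highest of the three numbers measured so far. Compound 2 `CC(=O)Nc1ccc(Cc2noc(CCC(=O)Nc3ccccc3)n2)cc1` gives 34.2%, and compound 3 `CC(=O)Nc1ccc(Cc2noc(CCC(=O)Nc3ccccc3F)n2)cc1` gives 67.1%. Compound 4 `CC(=O)Nc1ccc(Cc2noc(CCC(=O)Nc3cccc(C)c3)n2)cc1` is not yet measured; it differs from compound 1 by (3-methylphenyl)amino in place of hydroxy on a carbonyl carbon. Two measured steps from compound 1 bear on this change: a number 41.1 percentage points lower from compound 1 to compound 2 (beyond the scatter) and a number 8.2 percentage points lower from compound 1 to compound 3 (within the scatter). Between the two anilides, a number 32.9 percentage points higher from compound 2 to compound 3 (beyond the scatter). A substituted aryl amide is thus associated with a smaller loss than the plain anilide, but only compound 3 shows this, and the (3-methylphenyl)amino group is not the (2-fluorophenyl)amino group. A moderate loss is expected for compound 4, a number 20.3 percentage points lower from compound 1 to compound 4 (beyond the scatter). The estimate for compound 4 is 55%, within a range of 32% to 76%.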

Compound 4, a percentage reported as inhibition, in the whole organism at one dose (the size of the read-out at that dose, not a potency): 16.4%
Compound 4: the middle estimate sits 38.6 percentage points above what was measured, and the stated range ends above it.
By their numbers in this assay, from the lowest: compound 4; then compound 2; then compounds 3 and 1 (each within the scatter of the next).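

An aryl amide at this carbonyl does not by itself keep the level of compound 1 in this assay: a number 58.9 percentage points lower from compound 1 to compound 4 (beyond the scatter), so the small step seen with (2-fluorophenyl)amino does not extend to (3-methylphenyl)amino. Substitution on the anilide is also no general gain: a number 17.8 percentage points lower from compound 2 to compound 4 (beyond the scatter), and a number 50.7 percentage points lower from compound 3 to compound 4 (beyond the scatter). Nothing available explains this split.

Compound 3 and compound 4 differ in both the substituent and its place, so these two effects remain unseparated. The 3-fluorophenyl and 2-methylphenyl amides would bear directly on that question.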